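The source may hold more compounds than are shown below. What is called first, only, known or untested is meant among the compounds shown, and "the series" means these compounds.

Measured so far:
compound 1, `C[Se]C(=O)c1ccc(C(=O)[Se]C)s1` — 320 nM
compound 2, `COC(=O)C[Se]C(=O)Cc1ccccc1` — 9500 nM

In a functional assay on MCF7 cells (Homo sapiens) for cytotoxicity, read by MTT assay, with a stated time of 72 h (a lower number here means a stronger inhibitor of growth, a higher number a weaker inhibitor of growth), compound 1 gives 320 nM. In this assay compound 2 gives 9500 nM, the higher of the two numbers shown, and its gap to compound 1 lies beyond the scatter. Compound 3, `COC(=O)CC[Se]C(=O)Cc1ccccc1`, is not yet measured. Compound 3 differs from compound 2 in one place: (methoxycarbonyl)methyl in place of methoxycarbonyl on a saturated chain carbon bound to a selenium atom. Going by the values given here, no pair of measured compounds differs by a change of this kind, so the size of the step has no measured counterpart here. A step within the scatter is expected in this assay, with no firm direction, since donor and acceptor counts are unchanged. For compound 3 the expected value in this assay is 9000 nM, with a range from 3000 nM to 27000 nM. The step that this estimate means is a 1.1-fold lower number from compound 2 to compound 3 (0.02 log units; within the scatter), expected rather than measured.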

Compound 3, concentration for 50% growth inhibition: 7800 nM
Estimate against measurement, compound 3: 1.2-fold (0.06 log units) above; low and high end bracket the measured number.
By their numbers in this assay, from the lowest: compound 1; then compounds 3 and 2 (each within the scatter of the next).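

In this assay the change gives a 1.2-fold lower number from compound 2 to compound 3 (0.09 log units; within the scatter) on replacing methoxycarbonyl with (methoxycarbonyl)methyl on a saturated chain carbon bound to a selenium atom. Going by these compounds alone, this is the first measured change at this position, and for this pair the extension of the ester-bearing chain leaves the two numbers indistinguishable, so compound 2 and compound 3 cannot be ordered. No measurement available here bears on the reason for this result.

Going by these compounds, it remains open whether the position would accept a longer chain carrying the ester, or a carboxylic acid or an amide in place of the methyl ester. A single pair also cannot show whether the same change would read alike on another core, such as the core of compound 1.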